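Side chain edits on the acylsulfonamide and passive permeability

The source may report more compounds than this note shows. Statements on the series, on what has been measured and on what is new or still open speak of the compounds shown alone.

Compounds measured so far:
Compound 1 `O=C(NS(=O)(=O)c1ccccc1)c1ccc(Nc2nc(NC3(c4ccc(Cl)cc4)CC3)nc(OCC(F)(F)F)n2)cc1`: 182 nm/s
Compound 2 `CC(C)(C)NC(=O)NCCS(=O)(=O)NC(=O)c1ccc(Nc2nc(NC3(c4ccc(Cl)cc4)CC3)nc(OCC(F)(F)F)n2)cc1`: 49 nm/s
Compound 3 `CC(C)C(=O)NCCS(=O)(=O)NC(=O)c1ccc(Nc2nc(NC3(c4ccc(Cl)cc4)CC3)nc(OCC(F)(F)F)n2)cc1`: 13 nm/s

In a physicochemical assay for permeability, using PAMPA, at pH 7.4 (on this read-out lower numbers stand for lower permeability and higher numbers for higher permeability), compound 2 holds the second highest of the three numbers; the steps of a 3.7-fold lower number from compound 1 to compound 2 (0.57 log units; beyond the scatter) and a 3.8-fold lower number from compound 2 to compound 3 (0.58 log units; beyond the scatter) place it apart from both neighbours, each beyond the scatter. Compound 4 `CC(C)(C)CNCCS(=O)(=O)NC(=O)c1ccc(Nc2nc(NC3(c4ccc(Cl)cc4)CC3)nc(OCC(F)(F)F)n2)cc1` differs from compound 2 in one place: neopentyl in place of (tert-butyl)carbamoyl on an amine nitrogen. Within the data shown here, no measured step makes this same change. The nearest, a 3.8-fold lower number from compound 2 to compound 3 (0.58 log units; beyond the scatter), reworks the carbonyl end of the same chain and was modest; a 14-fold lower number from compound 1 to compound 3 (1.15 log units; beyond the scatter) was large. On this basis a modest lowering in this assay is expected for compound 4, a 2.0-fold lower number from compound 2 to compound 4 (0.29 log units; within the scatter). Compound 4 is thus estimated at 25 nm/s in this assay, with a range from 7 nm/s to 90 nm/s.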

Compound 4, apparent permeability: 651 nm/s
Estimate against measurement, compound 4: 26-fold (1.42 log units) below; measured number outside the range, above it.
By their numbers in this assay, from the lowest: compound 3; then compound 2; then compound 1; then compound 4.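

In this assay, a chain on the sulfonyl sulfur does not always give a lower number than phenyl: with 2-(neopentylamino)ethyl there is a 3.6-fold higher number from compound 1 to compound 4 (0.55 log units; beyond the scatter), the first such rise in the series. The group on the amine nitrogen carries large steps, with a 13-fold higher number from compound 2 to compound 4 (1.12 log units; beyond the scatter) on replacing (tert-butyl)carbamoyl and a 50-fold higher number from compound 3 to compound 4 (1.70 log units; beyond the scatter) on replacing isopropylcarbonyl. Nothing measured here explains these steps.

Going by these compounds, whether the rise follows the loss of the carbonyl or the neopentyl group itself remains open. Also open, on these data alone, is what a smaller methyl group or a carboxylic acid at the chain end would give.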